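This account rests on a few compounds, and the source may have more. Where it says the series, first, only, none or still open, it means among the compounds named here.

Measured so far:
Compound 1, `Cc1ccc(Nc2nc(-n3ccnc3C)cs2)cc1`: 1200 nM
Compound 2, `COc1ccc(C(=O)c2sc(Nc3ccc(F)cc3)nc2N)cc1`: > 10000 nM
Compound 3, `COc1cc(C(=O)c2sc(Nc3ccc(C)cc3)nc2N)cc(OC)c1OC`: 15 nM

All three were tested in a functional assay on FM3A cells (Mus musculus) for antiproliferative activity, read by cell counting, with a stated time of 2 days; a lower number here means a stronger inhibitor, a higher number a weaker inhibitor. Of the two plain numbers, compound 3 has the lowest; compound 1 sits well above it, and that gap is beyond the scatter of the measurement. For compound 2 the assay did not return a number at all: its result is a limit, (the limit of > 10000 nM in this assay, at which 1 of the 3 values shown sits), so it is only known that compound 2 is weaker than that boundary.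

Compound 4, `COc1ccc(Nc2nc(N)c(C(=O)c3cc(OC)c(OC)c(OC)c3)s2)cc1`, has not yet been measured. It differs from compound 3 in a single place: methoxy in place of methyl on an aromatic carbon. Everything else, including the shared core and the carbonyl-linked trimethoxyphenyl group, is kept. Within the data shown here, no pair of measured compounds shows the effect of this particular change, so there is no measured step to lean on. A swap of this kind, one small group for another on the same aromatic carbon, would usually be expected to move the number little, perhaps not beyond the scatter. The expected step of a 1.7-fold higher number from compound 3 to compound 4 (0.22 log units; within the scatter) is therefore small. Compound 4 is estimated to give about 25 nM in this assay, within a range from 8 nM to 80 nM.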

Compound 4, half-maximal inhibitory concentration: 2200 nM
Compound 4: the middle estimate sits 88-fold (1.94 log units) below what was measured; measured number above the stated range.
By their numbers in this assay, from the lowest: compound 3; then compounds 1 and 4 (each within the scatter of the next). At a limit, above all of these: compound 2.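

In this assay, methoxy in place of methyl on this one aromatic carbon gives a 150-fold higher number from compound 3 to compound 4 (2.17 log units; beyond the scatter), so this is a position where swapping one small group for another can matter greatly. The earlier compounds shown here differed in several places at once and could not tie the strength of compound 3 to any single part; here the shared core and the carbonyl-linked trimethoxyphenyl group stay the same, so the whole step belongs to the change from 4-methylphenyl to 4-methoxyphenyl on the amino link. What lies behind the step remains unexplained, as no measurement shown here bears on its cause.

With only methyl and methoxy compared directly at this carbon, one step cannot show whether methyl is especially favourable or methoxy especially unfavourable, and a plain hydrogen, a chloro group, an ethyl group or a hydroxyl group at the same place would help to tell these apart. Going by these compounds, it also remains open whether the same swap would cost as much if the trimethoxyphenyl group were replaced by a different group.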